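Oxazoline-to-thiazoline swap in a bis-sulfonyl series

The compounds below may be only part of what the source reports. "The series", "measured", "known", "first", "only" and "open" are said of these compounds alone.

Measured so far:
- compound 1, `O=S(=O)(/C=C/S(=O)(=O)c1ccc(Cl)cc1)CC1=NCCO1`: 85.5%
- compound 2, `O=S(=O)(CC1=NCCO1)c1c[nH]cc1S(=O)(=O)c1ccc(Cl)cc1`: 92.1%
- compound 3, `O=S(=O)(CC1=NCCS1)c1c[nH]cc1S(=O)(=O)c1ccc(Cl)cc1`: 41.4%

All three were tested in a functional assay for inhibition, tested at 100 uM; a higher number here means more inhibition at the concentration tested (going by the name of the read-out), a lower number less inhibition. Compound 1 and compound 2 carry different cores; the difference between the two cores is not broken down here, and their two values lie within the scatter of each other. Compound 3 is derived from compound 2 by a group of 5 heavy atoms (3 carbon, 1 nitrogen, 1 sulfur; one five-membered non-aromatic ring with 2 hetero atoms) in place of a group of 5 heavy atoms (3 carbon, 1 nitrogen, 1 oxygen; one five-membered non-aromatic ring with 2 hetero atoms), on a saturated chain carbon bound to a sulfonyl sulfur, and that change produced a number 50.7 percentage points lower from compound 2 to compound 3 (beyond the scatter).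

Compound 4, `O=S(=O)(/C=C/S(=O)(=O)c1ccc(Cl)cc1)CC1=NCCS1`, is the unmeasured member. Within the data shown here, it is derived from compound 1 by a group of 5 heavy atoms (3 carbon, 1 nitrogen, 1 sulfur; one five-membered non-aromatic ring with 2 hetero atoms) in place of a group of 5 heavy atoms (3 carbon, 1 nitrogen, 1 oxygen; one five-membered non-aromatic ring with 2 hetero atoms), on a saturated chain carbon bound to a sulfonyl sulfur, the same change as the one that leads from compound 2 to compound 3, at the same place. Among the measured compounds shown here, the only precedent for it is that one step, so the expectation for compound 4 rests on compound 2 and compound 3 alone, with the reservation that the core of compound 1 is not the core of compound 2.

The step expected from compound 1 to compound 4 in this assay is a number 45.5 percentage points lower from compound 1 to compound 4 (beyond the scatter), because of a number 50.7 percentage points lower from compound 2 to compound 3 (beyond the scatter). Compound 4 is therefore estimated to give 40% in this assay, with a range from 15% to 70%.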

Compound 4, a percentage reported as inhibition, at one concentration (the size of the read-out at that concentration, not a potency): 32.3%
Beside the measured number, compound 4's estimate is 7.7 percentage points above it; the measured number falls inside the stated range.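

In this assay, the five-membered non-aromatic ring with sulfur in place of the one with oxygen, on a saturated chain carbon bound to a sulfonyl sulfur, gives a number 53.2 percentage points lower from compound 1 to compound 4 (beyond the scatter), a large loss on the core of compound 1. The two cores shown respond to this change by a matching amount: the same change on two cores in this assay, a number 50.7 percentage points lower (beyond the scatter) from compound 2 to compound 3 and a number 53.2 percentage points lower (beyond the scatter) from compound 1 to compound 4, 2.5 percentage points apart, within the scatter of two such steps. Among these compounds, this supports carrying the step from one of these cores to the other in this assay, but it rests on only two matched pairs read at a single concentration, so it shows neither that the step would hold on a third core nor why the change lowers inhibition.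

Still open, as far as these compounds go, is whether another group at the same place, such as an amine or a carboxylic acid, would retain the inhibition seen with the oxygen-containing ring. Also open, from the compounds shown here alone, is whether the step keeps its size with a methoxy group or a nitrile in place of the chlorine.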